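The source may hold more compounds than are shown below. What is called first, only, known or untested is meant among the compounds shown, and "the series" means these compounds.

Compound 1 `CC(C)(C)c1ccc(C(=O)NCc2ccc(C(N)=O)cc2)cc1` was tested in an assay on HeLa cells with Bile acid receptor (Homo sapiens) as the target, read by a luciferase reporter, with a stated time of 24 h (on this read-out lower numbers stand for an effect already at smaller amounts and higher numbers for an effect only at larger amounts of compound), and gave 3800 nM. Within the data shown here, compound 2 `O=C(O)c1ccc(CNC(=O)c2ccc(-c3ccccc3)cc2)cc1`, the only other compound measured in the same assay, gave 440 nM. Of the two numbers on record, compound 1 therefore carries the higher one, and the gap to compound 2 lies beyond the usual scatter of the assay, so the two compounds are clearly separated. The step under consideration leads from compound 1 to compound 3 `CC(=O)c1ccc(CNC(=O)c2ccc(C(C)(C)C)cc2)cc1`, which has not yet been measured. The change is methyl in place of amino on a carbonyl carbon; put another way, carbamoyl gives way to acetyl. Among the measured compounds shown here, nothing in the two measured compounds tests this particular exchange, so no measured step guides the expectation directly. Compound 3 is estimated to come out at 6000 nM, with a plausible range from 2000 nM to 20000 nM. This estimate implies a step from compound 1 to compound 3 of a 1.6-fold higher number from compound 1 to compound 3 (0.20 log units; within the scatter), expected to be small and most likely within the scatter, if anything toward a higher number.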

Compound 3, half-maximal effective concentration: 100 nM
Beside the measured number, compound 3's estimate is 60-fold (1.78 log units) above it, and the stated range ends above it.
By their numbers in this assay, from the lowest: compound 3; then compound 2; then compound 1.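

In this assay, methyl in place of amino on a carbonyl carbon gives a large step (a 38-fold lower number from compound 1 to compound 3 (1.58 log units; beyond the scatter)), so the number at this position depends strongly on what that carbonyl carbon carries. Compounds 1 and 2 differ in more than one place and could not show this, whereas here a single exchange of one heavy atom, with the loss of the hydrogen-bond donor counted on the amino group, separates two compounds beyond the scatter. Nothing available explains why this exchange has so large an effect.

As far as these compounds go, it remains open whether the lower number is particular to acetyl or would also appear with an ethyl or methoxy group on that carbonyl carbon. Also open, from the compounds shown here alone, is whether acetyl in place of the carboxylic acid of compound 2 would bring a step of similar size.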